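Working notes: pyrrole to chlorophenyl swap in the growth assay

This account rests on a few compounds, and the source may have more. Where it says the series, first, only, none or still open, it means among the compounds named here.

compound 1 `N#C/C(=C\c1ccc[nH]1)C(=O)NCc1ccc(Cl)c(Cl)c1`: > 50000 nM
compound 2 `COc1ccc(CNC(=O)/C(C#N)=C/c2ccc(C)cc2)cc1`: 42000 nM
compound 3 `COc1ccc(CNC(=O)/C(C#N)=C/c2cccc3ccccc23)cc1`: 15000 nM

In a functional assay on SMA cells (Homo sapiens) for inhibition, read by MTT assay, with a stated time of 72 h (on this read-out lower numbers stand for stronger inhibition of growth and higher numbers for weaker inhibition of growth), compound 1 gives only a limit, > 50000 nM. This is the limit of > 50000 nM in this assay, at which 1 of the 3 values shown sits, so compound 1 stands at the weak end of what has been measured and carries no number of its own. In this assay compound 2 gives 42000 nM. In this assay compound 3 gives 15000 nM. For the measured compounds named here, compounds 2 and 3 carry a different amide part from compound 1, so neither forms a single-point step with it; their two values show only that other members reach measurable numbers in this assay.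

Compound 4 `N#C/C(=C\c1ccc(Cl)cc1)C(=O)NCc1ccc(Cl)c(Cl)c1` differs from compound 1 by 4-chlorophenyl in place of 1H-pyrrol-2-yl on a double-bonded chain carbon bound to a double-bonded chain carbon. Going by the values given here, no measured step covers this change. A modest shift toward stronger inhibition of growth is expected, an at least 1.6-fold lower number from compound 1 to compound 4 (0.22 log units; that floor lies within the scatter), although compound 1 has no number of its own and leaves the size of the shift uncertain. For compound 4 the expected value is 30000 nM, with a range from 8000 nM to 100000 nM.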

Compound 4, concentration for 50% growth inhibition: 33000 nM
Compound 4: middle estimate off by 1.1-fold (0.04 log units), on the low side, and the stated range covers the measured number.
By their numbers in this assay, from the lowest: compound 3; then compounds 4 and 2 (each within the scatter of the next). At a limit, above all of these: compound 1.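

For the compounds shown here, at the double-bonded chain carbon bound to a double-bonded chain carbon, 4-chlorophenyl in place of 1H-pyrrol-2-yl gives the only single-place comparison, and in this assay it reads as an at least 1.5-fold lower number from compound 1 to compound 4 (0.18 log units; that floor lies within the scatter). Going by these compounds alone, with this amide part, compound 4 gives a measured number, 33000 nM, which the earlier compounds did not show. The step has only a floor, and its true size stays unknown, because compound 1 stands at a limit: the limit of > 50000 nM in this assay, at which 1 of the 4 values shown sits.

The compounds shown do not separate the loss of the ring nitrogen from the gain of chlorine, and a plain phenyl at this place would be needed to read the two apart. As far as these compounds go, how a carboxylic acid or a dimethylamino group at the same place would read also stays open.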